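Oxadiazole aryl exchange on the shared pyridazinone core

The source may hold more compounds than are shown below. What is called first, only, known or untested is meant among the compounds shown, and "the series" means these compounds.

Three compounds of the series have been run in a functional assay on the whole organism for inhibition, with Mythimna separata as the target, with a stated time of 5 days; on this read-out lower numbers stand for an effect already at smaller amounts and higher numbers for an effect only at larger amounts of compound. Compound 1 `CC(C)(C)n1ncc(OCc2nnc(-c3ccc(Br)cc3)o2)c(Cl)c1=O` gives 21.4 ug/mL and is the only one of the three with a number. Compound 2 `CCn1ncc(OCc2nnc(-c3ccccc3)o2)c(Cl)c1=O` gives > 300 ug/mL, which is a limit of the assay and not a number. Compound 3 `CC(C)(C)n1ncc(OCc2nnc(-c3cc(F)c(Cl)c([N+](=O)[O-])c3Cl)o2)c(Cl)c1=O` gives > 300 ug/mL, again a limit and not a number. Within the data shown here, the picture is therefore (the limit of > 300 ug/mL in this assay, at which 2 of the 3 values shown sit), and compound 1 stands alone as the sole measured value, with no second number to set a step against it.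

Compound 4 `CC(C)(C)n1ncc(OCc2nnc(-c3cccs3)o2)c(Cl)c1=O` is not yet measured. It differs from compound 1 by thiophen-2-yl in place of 4-bromophenyl on an aromatic carbon. Among the measured compounds shown here, no measured pair isolates a change of this kind, so any expectation rests on the single number of compound 1 and on the two aryl groups occupying the same place on the shared core. The expected step from compound 1 to compound 4 in this assay is a 1.9-fold higher number from compound 1 to compound 4 (0.27 log units; within the scatter), a modest loss that may well stay within the usual scatter. Compound 4 is accordingly estimated at 40 ug/mL in this assay, with a range from 10 ug/mL to 200 ug/mL, and a fair chance that only a limit is reported.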

Compound 4, half-maximal effective concentration: > 300 ug/mL
Compound 4 was reported as a limit; the forecaster's own chance of this, stated with the estimate: 25%; at least 7.5-fold (0.87 log units) between middle value and limit.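

The aryl place on the five-membered aromatic ring of the shared core now has its first readable step: in this assay, thiophen-2-yl in place of 4-bromophenyl gives an at least 14-fold higher number from compound 1 to compound 4 (1.14 log units; beyond the scatter). That step rests on the limit reported for compound 4, so it fixes only the smallest possible size of the loss, not its true size. This place on the core of compound 1 therefore does not accept every aromatic group equally, and among the aryl groups shown on this core only 4-bromophenyl gives a number, which leaves the series with a single value set against a shared limit: the limit of > 300 ug/mL in this assay, at which 3 of the 4 values shown sit.

The compounds shown do not separate the loss of the bromine from the exchange of a six-membered carbon ring for a five-membered ring with sulfur, a question that 4-chlorophenyl or 4-methoxyphenyl at this place on the core of compound 1 would address. Also open, on these data alone, is whether thiophene can carry activity at all, for instance as a 5-bromothiophen-2-yl group, and how a 4-aminophenyl group would read out here.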